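This account rests on a few compounds, and the source may have more. Where it says the series, first, only, none or still open, it means among the compounds named here.

Measured compounds in a functional assay on HeLa cells (Homo sapiens) for inhibition, read by cell counting, with a stated time of 4 days; on this read-out lower numbers stand for stronger inhibition and higher numbers for weaker inhibition:
compound 1 `C=C(Br)C(=O)Nc1cccc(-c2cn3nc(-c4ccc(OC)c(OC)c4)sc3n2)c1` gives 610 nM;
compound 2 `C=C(Br)C(=O)Nc1cccc(-c2cn3nc(-c4ccc(OCC)cc4)sc3n2)c1` gives 1100 nM;
compound 3 `C=C(Br)C(=O)Nc1cccc(-c2cn3nc(-c4ccc(C)cc4)sc3n2)c1` gives 2000 nM.

Compound 3 stands at the highest number of the three, with a 1.8-fold higher number from compound 2 to compound 3 (0.26 log units; within the scatter) and a 3.3-fold higher number from compound 1 to compound 3 (0.52 log units; beyond the scatter). The step to compound 4 `C=C(Br)C(=O)Nc1cccc(-c2cn3nc(Cc4ccc(OC)cc4)sc3n2)c1` changes the same part of the shared core: 4-methoxybenzyl in place of 4-methylphenyl on an aromatic carbon. For the measured compounds named here, no measured step swaps an aryl group for a benzyl group, so the closest guides are the methyl-to-alkoxy comparisons, which gave at most a modest movement. A small step, if any, is therefore expected for compound 4, a 1.3-fold higher number from compound 3 to compound 4 (0.10 log units; within the scatter), with wide uncertainty. Compound 4 is estimated at 2500 nM, within a range from 800 nM to 8000 nM.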

Compound 4, half-maximal inhibitory concentration: 2300 nM
For compound 4 the middle estimate is 1.1-fold (0.04 log units) above the measured one; low and high end bracket the measured number.
By their numbers in this assay, from the lowest: compounds 1, 2, 3 and 4 (each within the scatter of the next, the first and the last beyond it).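

In this assay, 4-methoxybenzyl in place of 4-methylphenyl gives a 1.2-fold higher number from compound 3 to compound 4 (0.06 log units; within the scatter), so at this position a benzyl group and an aryl group cannot be told apart for this pair. The same 4-methoxybenzyl group still gives modest steps against the two alkoxy-bearing aryl groups, with a 2.1-fold higher number from compound 2 to compound 4 (0.32 log units; beyond the scatter) and a 3.8-fold higher number from compound 1 to compound 4 (0.58 log units; beyond the scatter). No data shown here explain these steps. Open, going by these compounds, is how this position responds to a group of another kind, such as an amine or a carboxylic acid, in place of the aromatic ring. Also open, on these data alone, is whether a longer chain between that ring and the shared core would move the number.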